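The source may hold more compounds than are shown below. What is called first, only, known or untested is meant among the compounds shown, and "the series" means these compounds.

Compound 1 (`C=C(CC)C(=O)c1ccc(OCC(=O)Nc2ccc(C(=O)O)cc2)c(Cl)c1Cl`), measured at (5000 nM)
Compound 2 (`C=C(CC)C(=O)c1ccc(OCC(=O)Nc2ccc(C#N)cc2)c(Cl)c1Cl`), measured at (7800 nM)

In a functional assay on CLL cells (Homo sapiens) for cytotoxicity, read by MTT assay, with a stated time of 48 h (on this read-out lower numbers stand for an effect already at smaller amounts and higher numbers for an effect only at larger amounts of compound), compound 2 stands at 7800 nM and lies within the scatter of compound 1 at 5000 nM so the two cannot be told apart. Compound 3 (`C=C(CC)C(=O)c1ccc(OCC(=O)Nc2ccc(C(=O)OC)cc2)c(Cl)c1Cl`) has not yet been measured. It differs from compound 2 by methoxycarbonyl in place of cyano on an aromatic carbon and so carries methoxycarbonyl in place of cyano on an aromatic carbon. Going by the values given here, one measured step bears on this exchange, a 1.6-fold higher number from compound 1 to compound 2 (0.19 log units; within the scatter) for cyano in place of carboxy, and it lies within the scatter. Methoxycarbonyl itself has no measured value among these compounds, so the comparison rests on this single step alone. No step beyond the scatter is therefore expected in this assay in either direction. The expected change is a 1.2-fold lower number from compound 2 to compound 3 (0.08 log units; within the scatter) and is estimated to remain within the scatter. For compound 3 the estimate is 6500 nM with an expected range from 2500 nM to 16000 nM for the measurement still to come.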

Compound 3, half-maximal effective concentration: 4100 nM
Estimate against measurement, compound 3: 1.6-fold (0.20 log units) above; the measured number falls inside the stated range.
By their numbers in this assay, from the lowest: compounds 3, 1 and 2 (each within the scatter of the next).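

In this assay, methoxycarbonyl in place of cyano, on an aromatic carbon para to a large group, gives a 1.9-fold lower number from compound 2 to compound 3 (0.28 log units; within the scatter), while methyl in place of hydrogen on an oxygen next to a carbonyl group gives a 1.2-fold lower number from compound 1 to compound 3 (0.09 log units; within the scatter). The earlier pair had tested only the carboxy and cyano groups at this position; with methoxycarbonyl as a third group, compound 1, compound 2 and compound 3 still cannot be told apart, so capping the carboxylic acid as its methyl ester leaves the number within the scatter as well. Nothing available explains why these exchanges leave the read-out within the scatter.

The compounds shown leave open whether any group at this position can move the number beyond the scatter, for example an amine, a primary carboxamide or a longer ester such as ethoxycarbonyl. They also leave open whether this tolerance holds once the shared core changes elsewhere, for instance if a chlorine is replaced by hydrogen or the ethyl chain is lengthened.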